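Phenylsulfonyl on the ring amine: expected cytotoxicity shift

This account rests on a few compounds, and the source may have more. Where it says the series, first, only, none or still open, it means among the compounds named here.

Measured in an ADME assay on L02 cells (Homo sapiens) for cytotoxicity, read by MTT assay, with a stated time of 24 h; on this read-out higher numbers stand for weaker inhibition and lower numbers for stronger inhibition:
Compound 1 `O=C1/C(=C/c2cccnc2)CN(S(=O)(=O)c2ccccc2)C/C1=C\c1ccccc1C(F)(F)F` gives 12500 nM
Compound 2 `O=C1/C(=C/c2ccncc2)CNC/C1=C\c1ccccc1C(F)(F)F` gives 13400 nM

The two measured compounds sit close together. Compound 2, at 13400 nM, stands within the scatter of compound 1, at 12500 nM. Among the measured compounds shown here, no measured step between compounds that differ in one place is available, so the size of the next step has no direct precedent.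

Compound 3 `O=C1/C(=C/c2ccncc2)CN(S(=O)(=O)c2ccccc2)C/C1=C\c1ccccc1C(F)(F)F` has phenylsulfonyl in place of hydrogen on an amine nitrogen in a ring of compound 2 (phenylsulfonyl in place of hydrogen on an amine nitrogen in a ring). Compound 1 also carries phenylsulfonyl on that nitrogen and gives 12500 nM, so no change beyond the scatter is expected in this assay. The expected step is small: a 1.2-fold lower number from compound 2 to compound 3 (0.09 log units; within the scatter). For compound 3 the estimated value is 11000 nM, with an expected range of 5000 nM to 25000 nM.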

Compound 3, half-maximal inhibitory concentration: 12300 nM
Estimate against measurement, compound 3: 1.1-fold (0.05 log units) below, within the range that was stated.
By their numbers in this assay, from the lowest: compounds 3, 1 and 2 (each within the scatter of the next).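

In this assay, phenylsulfonyl in place of hydrogen on the amine nitrogen in the ring now has a direct one-place comparison (a 1.1-fold lower number from compound 2 to compound 3 (0.04 log units; within the scatter)), so this read-out does not separate the two forms of that nitrogen. The swap of pyridin-3-yl for pyridin-4-yl also has its first direct comparison (a 1.0-fold lower number from compound 1 to compound 3 (0.01 log units; within the scatter)), and with phenylsulfonyl on the nitrogen, that change likewise stays within the scatter. Nothing measured here speaks to the reason for either result.

Open, going by these compounds, is whether a different group on that nitrogen, such as acetyl, methyl or benzyl, would give a step beyond the scatter. Also open, on these data alone, is whether pyridin-2-yl or a plain phenyl in place of the pyridin-4-yl group would do so.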